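Adding a methoxy group to compound 3

This account rests on a few compounds, and the source may have more. Where it says the series, first, only, none or still open, it means among the compounds named here.

Measured compounds:
- compound 1, `CNCCCNc1c(F)cc2c(=O)c(C(=O)O)cn(Cc3ccc(-c4ccccc4)cc3)c2c1OC`: 101000 nM
- compound 2, `COc1c(N2CC[C@@H](N)C2)c(F)cc2c(=O)c(C(=O)O)cn(Cc3ccc(-c4ccccc4)cc3)c12`: 92200 nM
- compound 3, `CNCCCCNc1cc2c(cc1F)c(=O)c(C(=O)O)cn2Cc1ccc(-c2ccccc2)cc1`: 88300 nM

All three were tested in an assay on isolated protein for inhibition of DNA topoisomerase 1 (Homo sapiens), with a stated time of 15 min; on this read-out lower numbers stand for stronger inhibition and higher numbers for weaker inhibition. Compound 3 gives the lowest of the three numbers, yet its gaps to compound 2 and to compound 1 are both within the scatter of repeated measurements, so the three cannot be told apart on this read-out.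

Compound 4, `CNCCCCNc1c(F)cc2c(=O)c(C(=O)O)cn(Cc3ccc(-c4ccccc4)cc3)c2c1OC`, is compound 3 with one change: methoxy in place of hydrogen on an aromatic carbon. The new group sits ortho to the (4-(methylamino)butyl)amino group and meta to the fluoro group.

For the measured compounds named here, the only measured step, a 1.1-fold lower number from compound 1 to compound 2 (0.04 log units; within the scatter), swaps the amine-bearing side chain and says nothing about a methoxy group. Compounds 1 and 2 do carry a methoxy group while compound 3 does not, but they differ from compound 3 in the side chain as well, so their values only show that with or without that group the numbers fall in the same range. Therefore no step beyond the scatter is expected for a 1.0-fold higher number from compound 3 to compound 4 (0.01 log units; within the scatter).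

Compound 4 is estimated at 90000 nM, with a range from 45000 nM to 180000 nM.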

Compound 4, half-maximal inhibitory concentration: > 200000 nM
Compound 4 ended at the assay's limit; the forecaster's own chance of this, stated with the estimate: 5%; middle value at least 2.2-fold (0.34 log units) from the limit.
By their numbers in this assay, from the lowest: compounds 3, 2 and 1 (each within the scatter of the next). At a limit, above all of these: compound 4.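

For the compounds shown here, on this assay, methoxy in place of hydrogen, ortho to the (4-(methylamino)butyl)amino group and meta to the fluoro group, is the first change here to give a step beyond the scatter: an at least 2.2-fold higher number from compound 3 to compound 4 (0.35 log units; beyond the scatter). With the methoxy group in place, the side chain also proves able to shift the number, since (4-(methylamino)butyl)amino in place of 3-aminopyrrolidin-1-yl gives an at least 2.1-fold higher number from compound 2 to compound 4 (0.33 log units; beyond the scatter), whereas the earlier side-chain swap gave only a 1.1-fold lower number from compound 1 to compound 2 (0.04 log units; within the scatter). Compound 4 sits at a limit of the assay, so the true size of both new steps remains unknown, and they are known only as floors: the limit of > 200000 nM in this assay, at which 1 of the 4 values shown sits.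

The one-carbon difference in chain length cannot be read as a real change, as the result is an at least 1.9-fold higher number from compound 1 to compound 4 (0.29 log units; that floor lies within the scatter). The compounds shown also leave open whether a hydroxy group or a chlorine atom on the same aromatic carbon would act as methoxy does, and whether an ethoxy group would push the number further.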